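Ester side-chain isomers on the shared core

The source may hold more compounds than are shown below. What is called first, only, known or untested is meant among the compounds shown, and "the series" means these compounds.

Measured so far:
compound 1 `C=C1C(=O)O[C@@H]2[C@H]3O[C@]3(C)CC/C=C(\C)[C@@H](OC(=O)C(C)(O)CC)C[C@@H]12` — 15.7 ug/mL
compound 2 `C=C1C(=O)O[C@@H]2[C@H]3O[C@]3(C)CC/C=C(\C)[C@@H](OC(=O)CC(C)(C)O)C[C@@H]12` — 18.2 ug/mL

In a functional assay on PC-3 cells (Homo sapiens) for cytotoxicity, read by MTT assay, with a stated time of 48 h (a lower number here means a stronger inhibitor, a higher number a weaker inhibitor), compound 1 gives 15.7 ug/mL and compound 2 gives 18.2 ug/mL. For the measured compounds named here, compound 2 stands with the higher of the two numbers, but the only measured step, a 1.2-fold higher number from compound 1 to compound 2 (0.06 log units; within the scatter), is within the scatter, so the two are not separable here.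

Compound 3 `C=C1C(=O)O[C@@H]2[C@H]3O[C@]3(C)CC/C=C(\C)[C@@H](OC(=O)C(C)C(C)O)C[C@@H]12` is not yet measured. It differs from compound 2 by 2-hydroxy-1-methylpropyl in place of 2-hydroxy-2-methylpropyl on a carbonyl carbon. Going by the values given here, the one measured step that bears on it is a 1.2-fold higher number from compound 1 to compound 2 (0.06 log units; within the scatter), which also exchanged one hydroxy-methylpropyl group for another on the carbonyl carbon without leaving the scatter. No step beyond the scatter exists in the series, so nothing points to a direction for the new exchange. The step of a 1.1-fold lower number from compound 2 to compound 3 (0.03 log units; within the scatter) is therefore expected to stay within the scatter. For compound 3 the estimate is 17 ug/mL, with a range of 9 ug/mL to 34 ug/mL.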

Compound 3, half-maximal inhibitory concentration: 11.3 ug/mL
For compound 3 the middle estimate is 1.5-fold (0.18 log units) above the measured one; the measured number falls inside the stated range.
By their numbers in this assay, from the lowest: compounds 3, 1 and 2 (each within the scatter of the next).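

With 2-hydroxy-1-methylpropyl on the carbonyl carbon, this assay shows a 1.6-fold lower number from compound 2 to compound 3 (0.21 log units; within the scatter) and also a 1.4-fold lower number from compound 1 to compound 3 (0.14 log units; within the scatter) within the same series. Compound 1, compound 2 and compound 3 carry the same atoms joined differently in this side chain, and all three steps among them now lie within the scatter, so a third arrangement at this position also gives no separable difference, where the earlier pair offered only two. The data on hand offer no measurement that accounts for this result.

The compounds shown vary only the arrangement of these hydroxy-methylpropyl isomers, so they leave open how this position responds to a different group, such as a longer chain, an amine or a carboxylic acid. They also leave open whether any change at this ester reaches beyond the scatter in this cell assay.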